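Methyl on the ring amine: same change on two cores

The compounds below may be only part of what the source reports. "The series", "measured", "known", "first", "only" and "open" are said of these compounds alone.

Compound 1 `COc1cc(OC)c(-c2nc(N3CCN(C)CC3)nc3ccccc23)c(OC)c1` and compound 2 `COc1cc(OC)c(-c2nc(N3CCNCC3)nc3ccccc23)c(OC)c1` share one core and differ only at the amine nitrogen in the ring. In a functional assay on DU-145 cells (Homo sapiens) for antiproliferative activity, read by MTT assay (a lower number here means a stronger inhibitor, a higher number a weaker inhibitor), compound 2 gives 50 ug/mL and compound 1 gives 50 ug/mL. The step of no change at the digits printed from compound 2 to compound 1 (within the scatter) belongs to the change (methyl in place of hydrogen on an amine nitrogen in a ring). Compound 3 `Cn1cc(-c2nc(N3CCNCC3)nc3ccccc23)c2ccccc21` carries a different core; the difference between the two cores is not broken down here. In this assay compound 3 gives 50 ug/mL, which stands level with compound 1 and with compound 2 within the scatter. Compound 4 `CN1CCN(c2nc(-c3cn(C)c4ccccc34)c3ccccc3n2)CC1` is the counterpart of compound 3 with the change (methyl in place of hydrogen on an amine nitrogen in a ring); its place reads word for word as the place of the change from compound 2 to compound 1, so it is the same change made on the other core. The step is expected to be no change at the digits printed from compound 3 to compound 4 (within the scatter), because on the core of compound 1 the same change gave no change at the digits printed from compound 2 to compound 1 (within the scatter). No further pattern is read into three values that all sit at one figure. Compound 4 in this assay is estimated at 50 ug/mL, with a range from 25 ug/mL to 100 ug/mL.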

Compound 4, half-maximal inhibitory concentration: 50 ug/mL
Compound 4: middle estimate and measured number agree at the digits printed; measured number inside the range.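

In this assay the change from piperazin-1-yl to 4-methylpiperazin-1-yl gives no change at the digits printed from compound 3 to compound 4 (within the scatter) on this core, the same reading as on the core of compound 1. The two steps agree: the same change on two cores in this assay, no change at the digits printed (within the scatter) from compound 2 to compound 1 and no change at the digits printed (within the scatter) from compound 3 to compound 4, 1.0-fold (0.00 log units) apart, within the scatter of two such steps. Among these compounds, this shows that the change carries between these two cores as a step within the scatter, but all four compounds sit at one figure, so it does not show that the change would read the same on a third core or in another assay, and no step of measurable size is available to test whether a real shift would carry over.

Open, from the compounds shown here alone, is whether an ethyl group, a longer chain such as butyl, or an acetyl group on the same ring nitrogen would leave the value where it stands. Also open, going by these compounds, is what an open-chain amine in place of piperazin-1-yl would give on either core.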